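A few compounds are considered here, and "the series" means these few. Any claim that something is new, unique, unknown or untested is made for them only; others in the source may bear on it.

Compound 1 `Cc1ccc(C(=O)NN(C(=O)c2cc(C)cc(C)c2)C(C)(C)C)cc1` and compound 2 `Cc1cc(C)cc(C(=O)N(NC(=O)c2ccc(Cl)cc2)C(C)(C)C)c1` share the same core and differ only in one group on an aromatic carbon. In an assay on cells for agonist activity at ecdysone receptor (Bombyx mori), read by a luciferase reporter, with a stated time of 24 h (a lower number here means that less compound is needed, a higher number that more compound is needed for the effect), compound 1 gives 12 nM and compound 2 gives 19.1 nM; the step of a 1.6-fold higher number from compound 1 to compound 2 (0.20 log units; within the scatter) keeps the two numbers within the scatter of each other, so compound 2 stands level with compound 1 in this assay. Compound 3 `CCCCC(=O)NN(C(=O)c1cc(C)cc(C)c1)C(C)(C)C` has not yet been measured. It differs from compound 2 by butyl in place of 4-chlorophenyl on a carbonyl carbon, that is, a whole ring is exchanged for a short chain. Among the compounds with values here, the only measured step, a 1.6-fold higher number from compound 1 to compound 2 (0.20 log units; within the scatter), concerns a small change on the ring that is now removed and says little about losing the ring itself. The change is therefore expected to matter more than that step, and the number for compound 3 is estimated at 2000 nM, between 200 nM and 20000 nM, which would mean a step of a 100-fold higher number from compound 2 to compound 3 (2.02 log units; beyond the scatter).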

Compound 3, half-maximal effective concentration: 1860 nM
The estimate for compound 3 lay 1.1-fold (0.03 log units) above the measured number; measured number inside the range.
By their numbers in this assay, from the lowest: compounds 1 and 2 (each within the scatter of the next); then compound 3.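

In this assay the earlier step showed only that chloro in place of methyl on the aromatic ring leaves the number within the scatter, whereas the new result shows that losing the whole ring on this carbonyl carbon matters far more. Butyl in place of 4-chlorophenyl brings a 97-fold higher number from compound 2 to compound 3 (1.99 log units; beyond the scatter), and butyl in place of 4-methylphenyl brings a 160-fold higher number from compound 1 to compound 3 (2.19 log units; beyond the scatter), so with either ring as the starting point, much more compound is needed once the short chain takes its place. No measurement shown here explains why the ring makes this difference.

Butyl is the only chain shown, so it remains open whether a longer chain such as hexyl would bring the number back down. On these data alone, it is also open whether a cyclohexyl ring, which has no aromatic ring, would behave like the aromatic groups or like butyl.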